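Amide substituent swap on the diamine series

This account rests on a few compounds, and the source may have more. Where it says the series, first, only, none or still open, it means among the compounds named here.

The series shares one core, seen in compound 1 `N[C@H]1CC[C@H](Nc2c(C(=O)NCc3ccc(Cl)cc3Cl)nc(Br)c3cccnc23)CC1` and compound 2 `NCCCCCCNc1c(C(=O)NCc2ccc(F)cc2)nc(Br)c2cccnc12`. In a functional assay on HCT-116 cells (Homo sapiens) for cytotoxicity, read by MTT assay, with a stated time of 72 h (on this read-out lower numbers stand for stronger inhibition and higher numbers for weaker inhibition), compound 1 gives 6000 nM, and in this assay compound 2 gives 7000 nM; the two numbers lie within the scatter of each other, so neither compound can be set apart from the other on this read-out. Compound 3 `C[C@H](NC(=O)c1nc(Br)c2cccnc2c1N[C@H]1CC[C@H](N)CC1)c1ccc(F)cc1` keeps the diamine side of compound 1 and differs on the amide side: 1-(4-fluorophenyl)ethyl in place of 2,4-dichlorobenzyl on an amide-type nitrogen. Compound 2 carries a fluorinated benzyl on the same amide nitrogen with a different amine chain and gives a number close to compound 1, so a large step is not anticipated. The step from compound 1 to compound 3 is expected as a 1.3-fold higher number from compound 1 to compound 3 (0.12 log units; within the scatter), that is, none beyond the scatter or at most a modest rise. Compound 3 is estimated at 8000 nM in this assay, within 3000 nM to 20000 nM.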

Compound 3, half-maximal inhibitory concentration: > 10000 nM
Compound 3: a limit, no number (the forecaster's own chance of this, stated with the estimate: 10%); at least 1.2-fold (0.09 log units) between middle value and limit.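

In this assay compound 3 gives > 10000 nM as a limit of the assay and not a number. With the diamine side held, the swap to 1-(4-fluorophenyl)ethyl on the amide-type nitrogen reads as an at least 1.6-fold higher number from compound 1 to compound 3 (0.22 log units; that floor lies within the scatter) and gives this position its first one-place comparison, though it does not establish a loss beyond the scatter. The size of the step remains unreadable because the result is only a limit: the limit of > 10000 nM in this assay, at which 1 of the 3 values shown sits.

The compounds shown do not separate the defined stereocentre from the exchange of two chlorines for one fluorine on the aromatic ring. An unsubstituted benzyl, a 4-fluorobenzyl or the opposite configuration of 1-(4-fluorophenyl)ethyl on the same nitrogen, with the diamine side held, would bear on that question.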